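Swapping a Saturated Ring for an Aromatic One

This account rests on a few compounds, and the source may have more. Where it says the series, first, only, none or still open, it means among the compounds named here.

Measured so far in a physicochemical assay for solubility, using the shake flask method, in simulated intestinal fluid, measured as kinetic solubility, with a stated time of 2 h, at 25 degrees C, at pH 6.5; on this read-out lower numbers stand for lower solubility and higher numbers for higher solubility:
- compound 1, `Cc1nc(C#N)c(N)c2c1C(=O)N(Cc1ccccc1)C2=O`: < 5000 nM
- compound 2, `CCCOC(=O)c1nc(C)c2c(c1N)C(=O)N(Cc1ccccc1)C2=O`: < 5000 nM
- compound 3, `Cc1noc(-c2nc(C)c3c(c2N)C(=O)N(CC2CCOCC2)C3=O)n1`: 5700 nM

Of the compounds shown here, three share one core and have been measured in this assay. For compound 1 the value given is a limit of the assay, not a number. For compound 2 the value is likewise a limit, not a number. Going by the values given here, compound 3 is therefore the only compound with a number of its own: it stands as the single readable point, with the other two sitting at the limit of < 5000 nM in this assay, at which 2 of the 3 values shown sit. Among the compounds with values here, the one step between compounds that differ in one place, a step that the two limits leave unreadable from compound 1 to compound 2, concerns a different position and cannot be read because both ends are limits.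

Compound 4, `Cc1noc(-c2nc(C)c3c(c2N)C(=O)N(Cc2ccc(Cl)cn2)C3=O)n1`, differs from compound 3 in a single place: 5-chloropyridin-2-yl in place of oxan-4-yl on a saturated chain carbon bound to an amide-type nitrogen in a ring. Within the data shown here, no measured step touches this position or this kind of exchange, so there is nothing among the measured compounds that points in a direction. The expectation for compound 4 therefore rests on compound 3 alone, and the estimated step of a 1.3-fold lower number from compound 3 to compound 4 (0.10 log units; within the scatter) is set at no change beyond the usual scatter. Compound 4 is accordingly expected to show 4500 nM, with a range from 1500 nM to 12000 nM, and with a real chance that only a limit is reported.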

Compound 4, solubility: < 5000 nM
Compound 4: a limit, no number; the forecaster's own chance of this, stated with the estimate: 50%; the middle value lies beyond the limit too.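

Going by these compounds alone, this exchange is the first one that can be read at this place, on a saturated chain carbon bound to an amide-type nitrogen in a ring: putting 5-chloropyridin-2-yl in place of oxan-4-yl gives an at least 1.1-fold lower number from compound 3 to compound 4 (0.05 log units; that floor lies within the scatter) in this assay. Compound 4 gives < 5000 nM, which is a limit and not a number. The step therefore has only a floor, and that floor alone does not separate the aromatic ring from the saturated one, while the set is left with just one readable point: the limit of < 5000 nM in this assay, at which 3 of the 4 values shown sit.

Going by these compounds, how far the true value of compound 4 lies from the limit stays unknown, so the full size of this exchange cannot be told. Also open, on these data alone, is whether a plain pyridin-2-yl ring without the chlorine, or a ring carrying an amine or a carboxylic acid, would give a number of its own at this place.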